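A few compounds are considered here, and "the series" means these few. Any claim that something is new, unique, unknown or untested is made for them only; others in the source may bear on it.

Series notes. Compound 1 `Cc1cc(N(Cc2ccc(C(=O)NCCC(=O)O)cc2)c2nc(-c3ccc(C(F)(F)F)cc3)cs2)ccc1C(C)C` and compound 2 `O=C(O)CCNC(=O)c1ccc(CN(c2ccc3c(c2)CCCC3)c2nc(-c3ccc(Cl)c(Cl)c3)cs2)cc1` share a core that carries an aryl group on a nitrogen on an aromatic ring. In an in vitro assay on BHK cells for displacement of a labelled ligand from gastric inhibitory polypeptide receptor (Homo sapiens), read by scintillation proximity assay (a lower number here means a stronger inhibitor, a higher number a weaker inhibitor), compound 1 gives 633 nM, and compound 2 gives 830 nM; the two numbers lie within the scatter of one another, so nothing separates them. Compound 3 `O=C(O)CCNC(=O)c1ccc(CN(c2ccc(SC(F)(F)F)cc2)c2nc(-c3ccc(C(F)(F)F)cc3)cs2)cc1` is not yet measured and differs from compound 1 by 4-((trifluoromethyl)sulfanyl)phenyl in place of 4-isopropyl-3-methylphenyl on a nitrogen on an aromatic ring. Within the data shown here, no measured pair shows this kind of change, so the step from compound 1 to compound 3 in this assay is expected to be a 1.1-fold higher number from compound 1 to compound 3 (0.04 log units; within the scatter), not beyond the scatter in either direction. Compound 3 is therefore estimated at 700 nM, with a range from 250 nM to 2000 nM.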

Compound 3, half-maximal inhibitory concentration: 777 nM
Beside the measured number, compound 3's estimate is 1.1-fold (0.05 log units) below it; the measured number falls inside the stated range.
By their numbers in this assay, from the lowest: compounds 1, 3 and 2 (each within the scatter of the next).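

Replacing 4-isopropyl-3-methylphenyl with 4-((trifluoromethyl)sulfanyl)phenyl on a nitrogen on an aromatic ring gives, in this assay, a 1.2-fold higher number from compound 1 to compound 3 (0.09 log units; within the scatter), the only single-place step shown in the series. At this position, therefore, two differently substituted phenyl groups give numbers that cannot be told apart. No measurement at hand bears on why this is so.

Going by these compounds, whether a phenyl carrying an amine or a carboxylic acid at this place would stay within the scatter remains open. So does whether any group here can move the number beyond it.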